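Compound 3 and the step to compound 4

The compounds below may be only part of what the source reports. "The series", "measured", "known", "first", "only" and "open" are said of these compounds alone.

compound 1 `C=C1[C@@H](OC(C)=O)C[C@@H]2[C@](C)(COC=O)[C@H](OC(C)=O)CC[C@@]2(C)[C@@H]1C[C@@H](Nc1ccc(F)cc1)C1=CCOC1=O` gives 12400 nM in a functional assay on MCF7 cells (Homo sapiens) for cytotoxicity, read by sulforhodamine B assay; a lower number here means a stronger inhibitor, a higher number a weaker inhibitor
compound 2 `C=C1[C@@H](OC(C)=O)C[C@@H]2[C@](C)(COC=O)[C@H](OC(C)=O)CC[C@@]2(C)[C@@H]1C[C@@H](Nc1ccc(OC)c(OC)c1)C1=CCOC1=O` gives > 50000 nM as a limit
compound 3 `C=C1[C@@H](OC(C)=O)C[C@@H]2[C@](C)(CO[Si](C)(C)C(C)(C)C)[C@H](OC(C)=O)CC[C@@]2(C)[C@@H]1C[C@@H](Nc1ccc(C(=O)O)cc1)C1=CCOC1=O` gives 3990 nM in this assay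

Of the two actual numbers, compound 3 has the lower value, 3990 nM against compound 1 at 12400 nM in the same readout. Compound 4 `C=C1[C@@H](OC(C)=O)C[C@@H]2[C@](C)(COC=O)[C@H](OC(C)=O)CC[C@@]2(C)[C@@H]1C[C@@H](Nc1ccc(C(=O)O)cc1)C1=CCOC1=O` differs from compound 3 by a group of 2 heavy atoms (1 carbon, 1 oxygen; no ring) in place of a group of 7 heavy atoms (6 carbon, 1 silicon; no ring), on an oxygen on a saturated carbon with formyl entering on an oxygen on a saturated carbon. Among the compounds with values here, the only measured step is an at least 4.0-fold higher number from compound 1 to compound 2 (0.60 log units; beyond the scatter) on an amine nitrogen, so it does not test this change directly. Formyl is shared with compound 1 at 12400 nM and so a modest rise is expected. The expected change is a 3.5-fold higher number from compound 3 to compound 4 (0.55 log units; beyond the scatter) in the direction of weaker inhibition. In this assay the expected value of compound 4 is 14000 nM with an estimated range of 5000 nM to 40000 nM for this measurement.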

Compound 4, half-maximal inhibitory concentration: 41700 nM
Beside the measured number, compound 4's estimate is 3.0-fold (0.47 log units) below it, outside the stated range (above it).
By their numbers in this assay, from the lowest: compound 3; then compound 1; then compound 4. At a limit, above all of these: compound 2.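

Until now only the group on the amine nitrogen had changed, but in this assay the oxygen on a saturated carbon also proves sensitive: formyl in place of the group of 7 heavy atoms gives a large step, a 10-fold higher number from compound 3 to compound 4 (1.02 log units; beyond the scatter). With formyl held in place, carboxy in place of fluoro on an aromatic carbon gives a 3.4-fold higher number from compound 1 to compound 4 (0.53 log units; beyond the scatter). On the amine nitrogen, 4-carboxyphenyl in place of 3,4-dimethoxyphenyl gives an at least 1.1-fold lower number from compound 2 to compound 4 (0.07 log units; that floor lies within the scatter). This step cannot be read as a difference, because compound 2 stands at a limit: the limit of > 50000 nM in this assay, at which 1 of the 4 values shown sits.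

Still open, from the compounds shown here alone, is how a free hydroxyl or a benzyl ether on that oxygen would read. Also open, going by these compounds, is whether the silyl-to-formyl step holds with other groups on the amine nitrogen.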